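The source may hold more compounds than are shown below. What is called first, only, known or untested is meant among the compounds shown, and "the series" means these compounds.

Series notes. Going by the values given here, compound 1 `Cc1cccc(C(=O)Nc2ccc3c(c2)CC(NS(=O)(=O)c2ccccc2)C3)c1-c1ccc(Cl)cc1` gives 100 nM in an assay on isolated protein for inhibition of microsomal triglyceride transfer protein large subunit (Homo sapiens) (on this read-out higher numbers stand for weaker inhibition and lower numbers for stronger inhibition), the lower of the two numbers measured so far, with compound 2 `COc1cccc(C(=O)Nc2ccc3c(c2)CC(NS(=O)(=O)c2ccccc2)C3)c1-c1ccc(Cl)cc1` closest at 110 nM. Among the compounds with values here, the only measured step, a 1.1-fold higher number from compound 1 to compound 2 (0.04 log units; within the scatter), changes an aromatic carbon substituent far from the sulfonyl group. Compound 3 `Cc1cccc(C(=O)Nc2ccc3c(c2)CC(NS(C)(=O)=O)C3)c1-c1ccc(Cl)cc1` differs from compound 1 by methyl in place of phenyl on a sulfonyl sulfur. Within the data shown here, no measured step touches the sulfonyl sulfur, so nothing in the data sets the size of this change in this assay. Compound 3 is expected to give about 300 nM. The range estimated for compound 3 runs from 80 nM to 1500 nM. The expected step, a 3.0-fold higher number from compound 1 to compound 3 (0.48 log units; beyond the scatter), points toward weaker inhibition.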

Compound 3, half-maximal inhibitory concentration: 100 nM
The estimate for compound 3 lay 3.0-fold (0.48 log units) above the measured number, and the stated range covers the measured number.
By their numbers in this assay, from the lowest: compounds 1, 3 and 2 (each within the scatter of the next).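

Going by these compounds alone, the sulfonyl sulfur, which no earlier step touched, carries methyl in place of phenyl in this assay with no readable shift (no change at the digits printed from compound 1 to compound 3 (within the scatter)). For this pair, the phenyl on that sulfur is therefore not required to keep the number, even though the change removes an aromatic ring. No evidence here explains this result.

Still open, as far as these compounds go, is whether a longer chain such as n-butyl, an amine such as dimethylamino, or a substituted phenyl on that sulfur would keep the number. From the compounds shown here alone, it is also open whether the same change holds alongside the methoxy of compound 2.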